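A Cyclic Group Replaces an Open One on a Second Core

This account rests on a few compounds, and the source may have more. Where it says the series, first, only, none or still open, it means among the compounds named here.

Of the compounds shown here, three have been measured in an ADME assay on L6 cells (Rattus norvegicus) for cytotoxicity, read by resazurin assay, with a stated time of 70 h; a lower number here means a stronger inhibitor, a higher number a weaker inhibitor. Compound 1 `CC(C)NC(=N)c1ccc2oc(-c3cccc(OCCCOc4ccccc4)c3)cc2c1` gives 26500 nM in this assay. Compound 2 `c1ccc(OCCCOc2cccc(-c3cc4cc(C5=NCCN5)ccc4o3)c2)cc1` carries a different group on the same core; in this assay compound 2 gives 6500 nM. The change between them is a group of 5 heavy atoms (3 carbon, 2 nitrogen; one five-membered non-aromatic ring with 2 hetero atoms) in place of a group of 6 heavy atoms (4 carbon, 2 nitrogen; no ring), on an aromatic carbon, and it produced a 4.1-fold lower number from compound 1 to compound 2 (0.61 log units; beyond the scatter).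

Compound 3 `CC(C)NC(=N)c1ccc2cc(-c3cccc(OCCCOc4ccccc4)c3)oc2c1` is built from the same atoms as compound 1, joined differently; the difference between the two cores is not broken down here. In this assay compound 3 gives 82300 nM, the highest of the three numbers, a step beyond the scatter from compound 1 and further still from compound 2.

Compound 4 `c1ccc(OCCCOc2cccc(-c3cc4ccc(C5=NCCN5)cc4o3)c2)cc1` has not yet been measured. It stands to compound 3 as compound 2 stands to compound 1: the change is a group of 5 heavy atoms (3 carbon, 2 nitrogen; one five-membered non-aromatic ring with 2 hetero atoms) in place of a group of 6 heavy atoms (4 carbon, 2 nitrogen; no ring), on an aromatic carbon, and the surroundings of the place are the same in their description, so this is the same change made on a second core. Among the compounds with values here, the one example of it, from compound 1 to compound 2, gave a modest lowering of the number. If that carries over, compound 4 is expected to give about 20000 nM in this assay, with a range from 8000 nM to 50000 nM. Within the data shown here, that expectation amounts to an estimated step of a 4.1-fold lower number from compound 3 to compound 4 (0.61 log units; beyond the scatter), resting only on the single earlier step seen between compound 1 and compound 2.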

Compound 4, half-maximal inhibitory concentration: 10100 nM
Compound 4: middle estimate off by 2.0-fold (0.30 log units), on the high side; measured number inside the range.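

In this assay, placing the group with the five-membered non-aromatic ring where the open group stood on the second core gave an 8.1-fold lower number from compound 3 to compound 4 (0.91 log units; beyond the scatter), so the change again went with a lower number. Set beside the earlier step, the two results can be treated as one effect of about the same size, since the gap between them is no larger than repeated measurements would produce: the same change on two cores in this assay, a 4.1-fold lower number (0.61 log units; beyond the scatter) from compound 1 to compound 2 and an 8.1-fold lower number (0.91 log units; beyond the scatter) from compound 3 to compound 4, 2.0-fold (0.30 log units) apart, within the scatter of two such steps. This shows that the change carried over between these two cores, in direction and within the scatter in size, but two pairs cannot show that it would carry over to any further core, and they do not show which feature of the entering group goes with the lower number.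

The compounds shown leave open whether a ring as such matters, as they include neither a six-membered cyclic counterpart of the entering group nor an open group without the isopropyl substituent, such as the unsubstituted amidine. They also leave open whether the same step would appear with a longer chain in the part of the molecule that carries the terminal phenoxy group, or with a simple amine in place of either group.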